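The source may hold more compounds than are shown below. What is called first, only, known or untested is meant among the compounds shown, and "the series" means these compounds.

The series shares one core, seen in compound 1 `Cc1cc(N(C)C)nc(NCc2ccccc2)n1`, compound 2 `COc1cc(Nc2nc(C)cc(N3CCCCC3)n2)ccc1F` and compound 3 `Cc1cc(Nc2ccc(F)cc2)nc(NCc2ccccc2)n1`. In a physicochemical assay for solubility, read by nephelometry, measured as kinetic solubility (a higher number here means a more soluble compound, a lower number a less soluble compound), compound 1 gives > 250000 nM, which is a limit of the assay and not a number. Compound 2 gives 160000 nM in this assay. Compound 3 gives > 250000 nM, again a limit of the assay rather than a number. Compound 3 therefore stands at the limit of > 250000 nM in this assay, at which 2 of the 3 values shown sit. The next compound, compound 4 `COc1cccc(Nc2cc(C)nc(NCc3ccccc3)n2)c1`, differs from compound 3 by 3-methoxyphenyl in place of 4-fluorophenyl on a nitrogen on an aromatic ring. Within the data shown here, no measured pair shows this change, so no step size is known for it. The step from compound 3 to compound 4 in this assay is expected to stay within the scatter, a number no higher from compound 3 to compound 4 (the limit leaves the size open). Compound 4 is expected to give 250000 nM in this assay, with a range of 120000 nM to 400000 nM, most likely reported again as a limit.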

Compound 4, solubility: > 250000 nM
Compound 4 was reported as a limit; the forecaster's own chance of this, stated with the estimate: 60%; the middle value sits exactly at the limit.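

Compound 3 and compound 4 both stand at a limit of this assay, so no step can be read between them. The compounds shown leave open the size of any step for 3-methoxyphenyl in place of 4-fluorophenyl.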